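Swapping the Acetoxyphenyl Arm for a Dimethylphenyl

This account rests on a few compounds, and the source may have more. Where it says the series, first, only, none or still open, it means among the compounds named here.

This set of compounds was tested in a functional assay on DU-145 cells (Homo sapiens) for inhibition, read by trypan blue exclusion, with a stated time of 96 h; on this read-out higher numbers stand for weaker inhibition of growth and lower numbers for stronger inhibition of growth. Compound 1, with the structure `CC(=O)Oc1ccc(/C=C(\C(=O)c2ccc(Cl)cc2)S(=O)(=O)c2ccc(C)cc2)cc1`, gives 25000 nM in this assay. Among the two plain numbers shown it stands as the highest, that is the weaker of the two. The other number belongs to compound 3, `Cc1ccc(S(=O)(=O)/C(=C/c2ccc(Oc3ccccc3)cc2)C(=O)c2ccc(Cl)cc2)cc1`, which gives 1000 nM; the change is a 25-fold lower number from compound 1 to compound 3 (1.40 log units; beyond the scatter). Compound 2, `O=C(O)c1ccc(/C=C(/SCc2ccc(Cl)cc2)C(=O)c2ccc(C(=O)O)cc2)cc1`, is a different case: in this assay compound 2 gives only > 100000 nM, which is a limit of the assay rather than a measured number, as described by the limit of > 100000 nM in this assay, at which 1 of the 3 values shown sits.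

Compound 4, `Cc1ccc(S(=O)(=O)/C(=C/c2cc(C)ccc2C)C(=O)c2ccc(Cl)cc2)cc1`, has not yet been measured. It differs from compound 1 in one place: 2,5-dimethylphenyl in place of 4-acetoxyphenyl on a double-bonded chain carbon bound to a double-bonded chain carbon. For the measured compounds named here, no measured pair repeats this exact exchange. Going by the values given here, the only step that touches the same arm is the one from compound 1 to compound 3, where swapping a group on the oxygen brought a large gain, so the 4-acetoxyphenyl arm of compound 1 seems open to improvement, though the 2,5-dimethylphenyl carries no oxygen at all. A moderate step toward stronger inhibition is therefore expected, with wide uncertainty. For compound 4 the estimate is 8000 nM, between 2000 nM and 30000 nM, which is expected to mean a 3.1-fold lower number from compound 1 to compound 4 (0.49 log units; beyond the scatter).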

Compound 4, concentration for 50% growth inhibition: 1000 nM
Estimate against measurement, compound 4: 8.0-fold (0.90 log units) above, and the stated range ends above it.
By their numbers in this assay, from the lowest: compounds 3 and 4 (each within the scatter of the next); then compound 1. At a limit, above all of these: compound 2.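

Replacing the 4-acetoxyphenyl of compound 1 with 2,5-dimethylphenyl gives, in this assay, a 25-fold lower number from compound 1 to compound 4 (1.40 log units; beyond the scatter), so a large gain at this arm does not need an oxygen on the ring, since the entering group carries none and has no hydrogen-bond acceptors. Until now the only gain at this arm came from exchanging the acetyl on the oxygen for a phenyl, which kept that oxygen in place; compound 3 gives 1000 nM and compound 4 gives 1000 nM, values within the scatter of each other, so two quite different arms cannot be told apart on this read-out. Nothing measured in this set explains why the exchange in compound 4 has so large an effect on growth inhibition.

From the compounds shown here alone, what remains open is whether the gain depends on having two methyl groups and on where they sit on the ring, or would also appear with a single methyl or an unsubstituted phenyl. It is also unclear how this arm would respond to an amine or a nitrile, groups that do not appear on it in any of these compounds.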